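Fluoro in place of ethyl on the anilino ring

This account rests on a few compounds, and the source may have more. Where it says the series, first, only, none or still open, it means among the compounds named here.

Measured so far in a functional assay for inhibition, with Homo sapiens as the target; a lower number here means a stronger inhibitor, a higher number a weaker inhibitor:
- compound 1, `CCc1ccc(Nc2nccc(-c3ccncc3)n2)cc1`, gives 7700 nM
- compound 2, `Fc1ccc(Nc2nccc(-c3ccncc3)n2)cc1`, gives 1900 nM
- compound 3, `CCc1cccc(Nc2nccc(-c3ccncc3)n2)c1`, gives 10600 nM

Compound 1 and compound 3 have the same atoms joined differently; the difference between the two cores is not broken down here. Their two values are within the scatter of each other, so nothing is read into their order.

For the measured compounds named here, the one change measured is fluoro in place of ethyl on an aromatic carbon, and it made a 4.1-fold lower number from compound 1 to compound 2 (0.61 log units; beyond the scatter) in this assay.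

Compound 4, `Fc1cccc(Nc2nccc(-c3ccncc3)n2)c1`, is not yet measured. It differs from compound 3 by fluoro in place of ethyl on an aromatic carbon. This is the same kind of change as that from compound 1 to compound 2, not the same change: in compound 2 the fluoro sits para to a large group, in compound 4 it sits meta to a large group. Going by the values given here, only a single instance of the change has been measured, so how far the size carries over to the other place is open.

For compound 4 a step of about a 3.5-fold lower number from compound 3 to compound 4 (0.55 log units; beyond the scatter) in this assay is expected, resting on the step of a 4.1-fold lower number from compound 1 to compound 2 (0.61 log units; beyond the scatter) and on the value of compound 3, 10600 nM. The estimate for compound 4 is 3000 nM, with a range from 1200 nM to 8000 nM.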

Compound 4, half-maximal inhibitory concentration: 700 nM
For compound 4 the middle estimate is 4.3-fold (0.63 log units) above the measured one; the whole stated range lies above it.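

In this assay fluoro in place of ethyl again gives a lower number, here a 15-fold lower number from compound 3 to compound 4 (1.18 log units; beyond the scatter) and so the direction of the change is shared by the two cores shown. The size of the step is not shared, and the comparison of the two steps reads as follows: the same change on two cores in this assay, a 4.1-fold lower number (0.61 log units; beyond the scatter) from compound 1 to compound 2 and a 15-fold lower number (1.18 log units; beyond the scatter) from compound 3 to compound 4, 3.7-fold (0.57 log units) apart, beyond the scatter of two such steps

For planning in this series, the earlier step on the core of compound 1 therefore cannot serve as a measure of the step on another core, though with only two instances the result shows neither what sets the size nor how the change would behave on any further core.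

The compounds shown leave open whether the step follows the arrival of fluoro or the departure of ethyl, and a chlorine atom, a methoxy group or a longer chain on the same aromatic carbon would help to separate the two. Also open, going by these compounds, is how an amine or a carboxylic acid at that place would read in this assay and whether the difference between the two cores would persist with those groups.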